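This account rests on a few compounds, and the source may have more. Where it says the series, first, only, none or still open, it means among the compounds named here.

Measured so far:
compound 1 `CN1CCN(c2ccc(Nc3ncc(/N=C/c4ccccc4)c(NC4CCCC4)n3)cc2)CC1` — > 100000 nM (a limit of the assay)
compound 2 `CN1CCN(c2ccc(Nc3ncc(/N=C/c4cccs4)c(NC4CCCC4)n3)cc2)CC1` — 33900 nM
compound 3 `CC(C)Nc1nc(Nc2ccc(N3CCN(C)CC3)cc2)ncc1/N=C/c1ccccc1` — > 100000 nM (a limit of the assay)

In a functional assay on MCF7 cells (Homo sapiens) for antiproliferative activity, read by MTT assay (a lower number here means a stronger inhibitor, a higher number a weaker inhibitor), compound 1 reaches only a limit, > 100000 nM. Compound 2 gives 33900 nM in this assay. Compound 3 likewise reaches only a limit, > 100000 nM. Going by the values given here, the one measured change, (thiophen-2-yl in place of phenyl on a carbon with a double bond to nitrogen), made an at least 2.9-fold lower number from compound 1 to compound 2 (0.46 log units; beyond the scatter). The two cores differ by isopropyl in place of cyclopentyl on a nitrogen on an aromatic ring, and that step, a step that the two limits leave unreadable from compound 1 to compound 3, stays unreadable because of the limit of > 100000 nM in this assay, at which 2 of the 3 values shown sit.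

Compound 4 `CC(C)Nc1nc(Nc2ccc(N3CCN(C)CC3)cc2)ncc1/N=C/c1cccs1` carries the same change, (thiophen-2-yl in place of phenyl on a carbon with a double bond to nitrogen), on the core of compound 3. Given the measured step of an at least 2.9-fold lower number from compound 1 to compound 2 (0.46 log units; beyond the scatter), a step of similar size is expected here, an at least 2.2-fold lower number from compound 3 to compound 4 (0.34 log units; beyond the scatter); since compound 3 gives only a limit, the outcome for compound 4 may itself be a limit. Compound 4 is therefore estimated at 45000 nM, between 15000 nM and 150000 nM.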

Compound 4, half-maximal inhibitory concentration: 91100 nM
The estimate for compound 4 lay 2.0-fold (0.31 log units) below the measured number; the range from low to high includes it.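

In this assay, thiophen-2-yl in place of phenyl on the core of compound 3 gives an at least 1.0-fold lower number from compound 3 to compound 4 (0.04 log units; that floor lies within the scatter), so the change may carry across the two cores, but equal transfer is not shown: the same change on two cores in this assay, an at least 2.9-fold lower number (0.46 log units; beyond the scatter) from compound 1 to compound 2 and an at least 1.0-fold lower number (0.04 log units; that floor lies within the scatter) from compound 3 to compound 4; the limit leaves it open whether they differ. With thiophen-2-yl held constant, isopropyl in place of cyclopentyl gives a 2.7-fold higher number from compound 2 to compound 4 (0.43 log units; beyond the scatter), so the two cores do not behave alike in this pair. On these data alone, the exact size of the change on either core stays unknown, and the step that joins the two limits cannot be read: the limit of > 100000 nM in this assay, at which 2 of the 4 values shown sit.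

Still open, as far as these compounds go, is whether a furan-2-yl ring or a phenyl ring carrying an amine would follow thiophen-2-yl. Also open, from the compounds shown here alone, is how a longer chain on the same nitrogen would compare with isopropyl and cyclopentyl.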